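From Acetoxy to Hydroxy in a Cell Assay

A few compounds are considered here, and "the series" means these few. Any claim that something is new, unique, unknown or untested is made for them only; others in the source may bear on it.

In a functional assay on KB 3-1 cells (Homo sapiens), with a stated time of 1 h (a lower number here means that less compound is needed, a higher number that more compound is needed for the effect), compound 1 (`CC(=O)Oc1c(O)cc2oc(-c3ccccc3)cc(=O)c2c1O`) gives 11000 nM and compound 2 (`CC(=O)Oc1cc2oc(-c3ccccc3)cc(=O)c2c(OC(C)=O)c1OC(C)=O`) gives 6800 nM while compound 3 (`CC(=O)Oc1cc2oc(-c3ccccc3)cc(=O)c2c(O)c1OCc1ccccc1`) gives 2400 nM as the lowest of the three numbers, beyond the scatter from both others.

Compound 4 (`O=c1cc(-c2ccccc2)oc2cc(O)c(OCc3ccccc3)c(O)c12`) departs from compound 3 by acetoxy to hydroxy, with hydrogen in place of acetyl on an oxygen on an aromatic ring. Going by the values given here, no measured pair shows this change alone, so its size can only be judged loosely. Compound 1 at 11000 nM carries more free hydroxy than compound 3 and has the higher number, which hints at a move upward. Yet compound 2 at 6800 nM has no free hydroxy and also has a higher number than compound 3, so the hint is weak. A small move to a higher number, probably within the scatter, is expected, and the estimated step is a 1.9-fold higher number from compound 3 to compound 4 (0.27 log units; within the scatter) in this reading. Compound 4 is estimated at 4500 nM with an expected range from 1800 nM to 11000 nM in this estimate.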

Compound 4, half-maximal effective concentration: 1800 nM
The estimate for compound 4 lay 2.5-fold (0.40 log units) above the measured number; the measured number falls inside the stated range.
By their numbers in this assay, from the lowest: compounds 4 and 3 (each within the scatter of the next); then compounds 2 and 1 (each within the scatter of the next).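

In this assay, hydrogen in place of acetyl on an oxygen on an aromatic ring gives a 1.3-fold lower number from compound 3 to compound 4 (0.12 log units; within the scatter), a step within the scatter, so for this pair the acetoxy and hydroxy forms cannot be told apart. Going by these compounds alone, the second single-place comparison, benzyl in place of acetyl on an oxygen on an aromatic ring, gives a 6.1-fold lower number from compound 1 to compound 4 (0.79 log units; beyond the scatter), which is beyond the scatter and is the only step here of that kind. Nothing measured here explains either step.

The compounds shown leave open how an amine, a carboxylic acid or a longer chain in place of the benzyl group would read in this assay. They also leave open whether the benzyl step would keep its size if the other oxygens carried acetyl rather than hydrogen.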